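This account rests on a few compounds, and the source may have more. Where it says the series, first, only, none or still open, it means among the compounds named here.

Compounds measured so far in a functional assay on CHO-K1 cells for agonist activity at Glucose-dependent insulinotropic receptor (Mus musculus), read by HTRF and cAMP accumulation, with a stated time of 30 min; a higher number here means that more compound is needed for the effect, a lower number that less compound is needed:
- compound 1, `CCc1cnc(N2CCC(CCCNc3ccc4c(c3)C(=O)CC4)CC2)nc1`, gives 167 nM
- compound 2, `CC(C)(C)OC(=O)N1CCC(CCCNc2ccc3c(c2)C(=O)CC3)CC1`, gives 123 nM
- compound 3, `CC(C)c1noc(N2CCC(CCCNc3ccc4c(c3)C(=O)CC4)CC2)n1`, not yet measured

Among the measured compounds shown here, compound 2 holds the lowest of the two numbers in this assay, but its only neighbour is compound 1, and a 1.4-fold lower number from compound 1 to compound 2 (0.13 log units; within the scatter) lies within the scatter, so the two compounds cannot be told apart on these data.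

Compound 3 differs from compound 2 by 3-isopropyl-1,2,4-oxadiazol-5-yl in place of tert-butoxycarbonyl on an amine nitrogen in a ring. For the measured compounds named here, the only measured step that bears on this position is a 1.4-fold lower number from compound 1 to compound 2 (0.13 log units; within the scatter), where a 5-ethylpyrimidin-2-yl group on the same ring nitrogen gave a number indistinguishable from that of the tert-butoxycarbonyl group. Both compounds share the rest of the structure with compound 3. On that basis the account expects no step beyond the scatter for compound 3 in this assay, that is a 1.2-fold higher number from compound 2 to compound 3 (0.09 log units; within the scatter). The estimated value for compound 3 is 150 nM, with a range from 50 nM to 450 nM.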

Compound 3, half-maximal effective concentration: 158 nM
The estimate for compound 3 lay 1.1-fold (0.02 log units) below the measured number, and the stated range covers the measured number.
By their numbers in this assay, from the lowest: compounds 2, 3 and 1 (each within the scatter of the next).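

In this assay the change to 3-isopropyl-1,2,4-oxadiazol-5-yl on the amine nitrogen in a ring gives a 1.3-fold higher number from compound 2 to compound 3 (0.11 log units; within the scatter) and a 1.1-fold lower number from compound 1 to compound 3 (0.02 log units; within the scatter) and so stays within the scatter on both sides. Among the compounds shown here, the earlier compounds offered only one comparison at this position, whereas three different groups can now be set against each other, one of them a five-membered aromatic ring with 3 hetero atoms, and none can be told apart from the others. Nothing at hand gives a reason for this sameness.

From the compounds shown here alone, whether the number stays the same with a plain hydrogen on this ring nitrogen, a methyl group or a carboxylic acid remains open. The compounds shown differ only at this nitrogen, so they say nothing about changes to the rest of the structure.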